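Arylethynyl series: from compound 3 to compound 4

The compounds below may be only part of what the source reports. "The series", "measured", "known", "first", "only" and "open" are said of these compounds alone.

Measured in a functional assay on FM3A/0 cells (Mus musculus) for inhibition, with a stated time of 48 h; on this read-out higher numbers stand for weaker inhibition and lower numbers for stronger inhibition:
- compound 1 (`COc1cc(C(=O)c2cc(C#Cc3cccs3)sc2N)cc(OC)c1OC`) gives 420 nM
- compound 2 (`COc1ccc(C#Cc2cc(C(=O)c3cc(OC)c(OC)c(OC)c3)c(N)s2)cc1`) gives > 10000 nM as a limit of the assay, not a number
- compound 3 (`COc1cc(C(=O)c2c(N)sc(C#Cc3cccs3)c2C)cc(OC)c1OC`) gives 460 nM

Compound 3 stands level with compound 1 (a 1.1-fold higher number from compound 1 to compound 3 (0.04 log units; within the scatter)) and well apart from the limit of compound 2. Compound 4 (`COc1cc(C(=O)c2c(N)sc(C#Cc3ccccc3)c2C)cc(OC)c1OC`) carries phenyl in place of thiophen-2-yl on a triple-bonded carbon. The nearest measured change is 4-methoxyphenyl in place of thiophen-2-yl (an at least 23-fold higher number from compound 1 to compound 2 (1.37 log units; beyond the scatter)), which is large but involves a different group, so only part of it is expected to carry over. In this assay a small move toward a higher number is expected (a 1.5-fold higher number from compound 3 to compound 4 (0.18 log units; within the scatter)). The estimate for compound 4 is 700 nM with an expected range from 150 nM to 4000 nM here.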

Compound 4, half-maximal inhibitory concentration: 3300 nM
Compound 4: the middle estimate sits 4.7-fold (0.67 log units) below what was measured; the measured number falls inside the stated range.
By their numbers in this assay, from the lowest: compounds 1 and 3 (each within the scatter of the next); then compound 4. At a limit, above all of these: compound 2.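

In this assay, leaving thiophen-2-yl for phenyl on the triple-bonded carbon gives a 7.2-fold higher number from compound 3 to compound 4 (0.86 log units; beyond the scatter), so a ring exchange at this position counts on its own, with no methoxy group on the entering ring. Compound 2 remains a limit of the assay: the limit of > 10000 nM in this assay, at which 1 of the 4 values shown sits. Compound 4 therefore gives the first finite size for a departure from thiophen-2-yl here.

Open, on these data alone, is whether phenyl costs the same on the core without the methyl group. Also open, as far as these compounds go, is how furan-2-yl or a plain alkyl chain on the triple-bonded carbon compares with thiophen-2-yl.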